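Bromo in place of butoxy: working notes

A few compounds are considered here, and "the series" means these few. Any claim that something is new, unique, unknown or untested is made for them only; others in the source may bear on it.

Measured so far in a functional assay on M21 cells (Homo sapiens) for antiproliferative activity, read by sulforhodamine B assay, with a stated time of 48 h (on this read-out lower numbers stand for stronger inhibition and higher numbers for weaker inhibition), for the series:
- compound 1 `O=C1NCCN1c1ccc(S(=O)(=O)Nc2ccc(C3CCCCC3)cc2)cc1` gives > 1000 nM as a limit of the assay, not a number
- compound 2 `CCc1cccc(NS(=O)(=O)c2ccc(N3CCNC3=O)cc2)c1` gives 82 nM as a number
- compound 3 `CCCCOc1ccc(NS(=O)(=O)c2ccc(N3CCNC3=O)cc2)cc1` gives 580 nM as a number

Of the two true numbers, compound 3 holds the higher one, and the gap to compound 2 lies beyond the scatter.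

Compound 4 `O=C1NCCN1c1ccc(S(=O)(=O)Nc2ccc(Br)cc2)cc1` has bromo in place of butoxy on an aromatic carbon, para to a large group (bromo in place of butoxy on an aromatic carbon). Within the data shown here, one measured step concerns the same group, with butoxy in place of cyclohexyl on an aromatic carbon: an at least 1.7-fold lower number from compound 1 to compound 3 (0.23 log units; that floor lies within the scatter) and no more than that. Compound 1 stands at the limit of > 1000 nM in this assay, at which 1 of the 3 values shown sits, and so offers only a floor for that step. Among the measured compounds shown here, no measured step links compound 2 with compound 3, so their gap sets no size for this change.

No step beyond the scatter is therefore expected in this assay for this change, at most a small move towards a lower number. The expected change is a 1.5-fold lower number from compound 3 to compound 4 (0.16 log units; within the scatter) and it stays within the scatter. Compound 4 is estimated at 400 nM with expected bounds from 130 nM to 1200 nM on this read-out.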

Compound 4, half-maximal inhibitory concentration: 130 nM
The estimate for compound 4 lay 3.1-fold (0.49 log units) above the measured number; measured number inside the range.
By their numbers in this assay, from the lowest: compounds 2 and 4 (each within the scatter of the next); then compound 3. At a limit, above all of these: compound 1.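

In this assay, among these compounds, the swap on this aromatic carbon, para to a large group, now has a size beyond the scatter: a 4.5-fold lower number from compound 3 to compound 4 (0.65 log units; beyond the scatter), whereas the one earlier step at this place gave only a floor within the scatter. Replacing the butoxy chain with bromo also brings this series of para groups level with the 3-ethylphenyl compound, as a 1.6-fold higher number from compound 2 to compound 4 (0.20 log units; within the scatter) lies within the scatter, so 4-bromophenyl and 3-ethylphenyl on the sulfonamide nitrogen cannot be separated in this read-out. The change from cyclohexyl to bromo reads as an at least 7.6-fold lower number from compound 1 to compound 4 (0.88 log units; beyond the scatter), a step beyond the scatter that gives a floor and no true size, since compound 1 stands at a limit: the limit of > 1000 nM in this assay, at which 1 of the 4 values shown sits.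

Going by these compounds, whether the lower number belongs to bromo itself or simply to the loss of the larger butoxy and cyclohexyl groups stays open, and a chloro, a methyl or a methoxy at this place would separate the two readings. Also open is how this place responds to an amine or a carboxylic acid, as all three groups shown here are uncharged.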